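A few compounds are considered here, and "the series" means these few. Any claim that something is new, unique, unknown or untested is made for them only; others in the source may bear on it.

In a functional assay on NCI-H1299 cells (Homo sapiens) for antiproliferative activity, read by fluorescence and resazurin assay, with a stated time of 48 h (a lower number here means a stronger inhibitor, a higher number a weaker inhibitor), compound 1 `COc1ccc(Cn2cc(-c3ccc(O)cc3)c(-c3ccc(O)cc3)c2)cc1` gives 37300 nM. Only one other close relative has a measurement there: compound 2 `Oc1ccc(-c2cn(Cc3ccccc3)cc2-c2ccc(O)cc2)cc1` gives 26900 nM, and the two numbers lie within the scatter of each other. Compound 3 `COc1cccc(Cn2cc(-c3ccc(O)cc3)c(-c3ccc(O)cc3)c2)c1` keeps the shared core and differs from compound 1 in a single place: 3-methoxyphenyl in place of 4-methoxyphenyl on a saturated chain carbon bound to an aromatic nitrogen. That is, 3-methoxyphenyl stands in place of 4-methoxyphenyl on a saturated chain carbon bound to an aromatic nitrogen, so the two compounds have the same atoms, joined differently.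

Going by the values given here, one measured step bears on this change, and it removes that methoxy group altogether: a 1.4-fold lower number from compound 1 to compound 2 (0.14 log units; within the scatter), with hydrogen in place of methoxy on an aromatic carbon. Among the compounds with values here, no measured compound yet carries the group in its new place, so the evidence is indirect. Even so, if losing the group entirely leaves the number within the scatter, moving it is expected to do no more than that in this assay. The expected change is small, a 1.1-fold lower number from compound 1 to compound 3 (0.05 log units; within the scatter), with no direction beyond the scatter. For compound 3 the estimate is 33000 nM, with an expected range from 17000 nM to 62000 nM.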

Compound 3, half-maximal inhibitory concentration: 25300 nM
Estimate against measurement, compound 3: 1.3-fold (0.12 log units) above; low and high end bracket the measured number.
By their numbers in this assay, from the lowest: compounds 3, 2 and 1 (each within the scatter of the next).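

In this assay, the direct swap of 3-methoxyphenyl for 4-methoxyphenyl on a saturated chain carbon bound to an aromatic nitrogen gives a 1.5-fold lower number from compound 1 to compound 3 (0.17 log units; within the scatter), so moving the methoxy group now has a measurement of its own rather than only the indirect reading from its removal. Adding methoxy to the unsubstituted benzyl compound at the new place gives a 1.1-fold lower number from compound 2 to compound 3 (0.03 log units; within the scatter), so neither the 4-methoxybenzyl nor the 3-methoxybenzyl compound is separated from the compound carrying hydrogen instead, and this position shows no measurable response to these changes across the three compounds. Nothing available offers an explanation for this lack of separation.

The compounds shown leave open whether a carboxylic acid or an amine on this aromatic ring, or a longer chain in place of the saturated chain carbon, would move the number beyond the scatter. All three also keep the shared core unchanged, so they say nothing about how the number responds to changes there.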